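A few compounds are considered here, and "the series" means these few. Any claim that something is new, unique, unknown or untested is made for them only; others in the source may bear on it.

In a functional assay on NCI-H460 cells (Homo sapiens) for cytotoxicity, read by MTT assay, with a stated time of 48 h (on this read-out lower numbers stand for stronger inhibition and higher numbers for weaker inhibition), compound 1 `COc1ccc2[nH]c(-c3ccc[se]3)cc(=O)c2c1OC` gives 91500 nM. Compound 2 `COc1ccc2[nH]c(-c3ccc(C)[se]3)cc(=O)c2c1OC`, which carries a methyl in place of hydrogen on an aromatic carbon of the five-membered ring, is reported in this assay only at a limit, > 50000 nM, so that the step that the limit leaves unreadable from compound 1 to compound 2 cannot be read, as the limit of > 50000 nM in this assay, at which 1 of the 2 values shown sits, shows. Compound 2 therefore stands only as a limit among the numbers shown, not as a measured value. Compound 3 `COc1ccc2[nH]c(-c3cc[se]c3)cc(=O)c2c1OC` differs from compound 2 by a group of 5 heavy atoms (4 carbon, 1 selenium; one five-membered aromatic ring with 1 hetero atom) in place of a group of 6 heavy atoms (5 carbon, 1 selenium; one five-membered aromatic ring with 1 hetero atom), on an aromatic carbon. The single measured step from compound 1 to compound 2 is unreadable, so no measured step bears on this change beyond the observation that both compounds shown lie in the weak range of this assay. No shift beyond the usual scatter is therefore expected, and compound 3 is estimated at 80000 nM, between 30000 nM and 200000 nM, an expected step that the limit leaves unreadable from compound 2 to compound 3.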

Compound 3, half-maximal inhibitory concentration: 100000 nM
Compound 3: middle estimate off by 1.3-fold (0.10 log units), on the low side; the range from low to high includes it.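

Within the data shown here, the one readable step at this place is a 1.1-fold higher number from compound 1 to compound 3 (0.04 log units; within the scatter). Compound 1 and compound 3 carry two differently arranged groups of 5 heavy atoms (4 carbon, 1 selenium), each one five-membered aromatic ring with 1 hetero atom, and this assay does not tell them apart. Compound 2 is reported only as a limit, so the steps that involve it cannot be read, and the methyl remains without a measured step: the limit of > 50000 nM in this assay, at which 1 of the 3 values shown sits.

The compounds shown leave open whether any group at this place gives a number clearly apart from these, since all of the readable values lie within the scatter of each other. Nor do they show how a five-membered aromatic ring with sulfur in place of selenium, or one bearing an amine, a carboxylic acid or a longer chain, would read here.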